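The compounds below may be only part of what the source reports. "The series", "measured", "known", "first", "only" and "open" are said of these compounds alone.

Going by the values given here, in a functional assay on T29Kt1 cells (Homo sapiens) for cytotoxicity, read by sulforhodamine B assay, with a stated time of 3 days (on this read-out lower numbers stand for stronger inhibition and higher numbers for weaker inhibition), compound 2 `Cc1ccc(Cn2cc(CO)c3ccccc32)cc1` gives 150 nM, the lowest of the two numbers measured so far. Among the compounds with values here, the only other measured compound, compound 1 `OCc1cn(Cc2ccc(Br)cc2)c2ccccc12`, gives 390 nM. The two share the same core and differ in a single group.

Compound 3 `O=[N+]([O-])c1ccc(Cn2cc(CO)c3ccccc32)cc1` keeps the core of compound 2 but carries nitro in place of methyl on an aromatic carbon, para to a large group (nitro in place of methyl on an aromatic carbon). Within the data shown here, only one measured step bears on this change: a 2.6-fold lower number from compound 1 to compound 2 (0.41 log units; beyond the scatter), with methyl in place of bromo on an aromatic carbon. That step is modest, yet it shows that swapping the group at this place can shift the number beyond the scatter. Among the measured compounds shown here, no compound with nitro has been measured, so the guide is thin and the direction is uncertain. For the measured compounds named here, since compound 2 already holds the lower number, a modest rise seems the more likely outcome, of about the size of the one known step. The expected change is a 1.9-fold higher number from compound 2 to compound 3 (0.27 log units; within the scatter). For compound 3 the estimated value in this assay is 280 nM, with an expected range from 90 nM to 800 nM.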

Compound 3, half-maximal inhibitory concentration: 150 nM
Compound 3: middle estimate off by 1.9-fold (0.27 log units), on the high side; the measured number falls inside the stated range.
By their numbers in this assay, from the lowest: compounds 2 and 3 (each within the scatter of the next); then compound 1.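

In this assay, putting nitro in place of methyl on this aromatic carbon gives no change at the digits printed from compound 2 to compound 3 (within the scatter) and so leaves the number where it was, even though nitro is the larger group by heavy atoms and brings hydrogen-bond acceptors that methyl lacks. Nitro in place of bromo gives a 2.6-fold lower number from compound 1 to compound 3 (0.41 log units; beyond the scatter) and matches the size of the earlier step from bromo to methyl, so among these three compounds bromo alone stands apart, while two quite different groups sit level at this position. No measurement shown here accounts for this result.

An amine, a carboxylic acid or a longer chain at the same place could show whether the level shared by compound 2 and compound 3 extends to other kinds of group, or whether methyl and nitro are simply a coincidental match. On these data alone, it also remains open whether methyl and nitro would still match when placed elsewhere on this ring, since all three groups compared here sit at the same place.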